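The compounds below may be only part of what the source reports. "The series", "measured", "known", "first", "only" and "open" are said of these compounds alone.

In a functional assay on MCF7 cells (Homo sapiens) for cytotoxicity, read by MTT assay, with a stated time of 96 h (a higher number here means a weaker inhibitor, a lower number a stronger inhibitor), three compounds sharing one core have been measured. Compound 1 (`COc1cc(C(=O)c2cn(-c3ccccc3)cc2-c2ccc(N)cc2)cc(OC)c1OC`) gives 9 nM, compound 2 (`COc1cc(C(=O)c2cn(-c3ccccc3)cc2-c2ccccc2C)cc(OC)c1OC`) gives 190 nM, and compound 3 (`COc1cc(C(=O)c2cn(-c3ccccc3)cc2-c2cccc([N+](=O)[O-])c2)cc(OC)c1OC`) gives 50 nM. Compound 3 therefore holds the middle place among the three numbers.

Compound 4 (`COc1cccc(-c2cn(-c3ccccc3)cc2C(=O)c2cc(OC)c(OC)c(OC)c2)c1`) differs from compound 3 by methoxy in place of nitro on an aromatic carbon, and the exchange is counted as methoxy in place of nitro on an aromatic carbon. Within the data shown here, no measured step makes this exact exchange. The closest evidence comes from steps that replace a whole substituted phenyl group: a 5.6-fold higher number from compound 1 to compound 3 (0.74 log units; beyond the scatter) and a 3.8-fold lower number from compound 2 to compound 3 (0.58 log units; beyond the scatter) are both modest, while a 21-fold higher number from compound 1 to compound 2 (1.32 log units; beyond the scatter) is large. All three lie beyond the scatter, so the number does respond to changes in this group. However, each of them alters more than the present exchange does, since compound 4 keeps its substituent where compound 3 has it. These steps favour no direction, so no step beyond the scatter is expected, and the estimated change is a 1.2-fold higher number from compound 3 to compound 4 (0.08 log units; within the scatter). For compound 4 the expected value is 60 nM, with an estimated range from 15 nM to 240 nM.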

Compound 4, half-maximal inhibitory concentration: 180 nM
Compound 4: middle estimate off by 3.0-fold (0.48 log units), on the low side; low and high end bracket the measured number.
By their numbers in this assay, from the lowest: compound 1; then compound 3; then compounds 4 and 2 (each within the scatter of the next).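

In this assay, among these compounds, the exchange of nitro for methoxy moves the number beyond the scatter (a 3.6-fold higher number from compound 3 to compound 4 (0.56 log units; beyond the scatter)), which shows that the group itself matters while its place, meta to a large group, stays the same; the earlier steps could not show this, since each replaced a whole substituted phenyl group. The 3-methoxyphenyl and 2-methylphenyl groups cannot be ordered (a 1.1-fold lower number from compound 2 to compound 4 (0.02 log units; within the scatter)), whereas the 4-aminophenyl group of compound 1 keeps the lowest number of the four, with a large step to the new compound (a 20-fold higher number from compound 1 to compound 4 (1.30 log units; beyond the scatter)). Nothing available explains why methoxy and nitro differ at this position.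

The compounds shown leave open how an amino group would behave at the place held by nitro and methoxy, so the contribution of the amine in compound 1 cannot be separated from that of its place on the ring. As far as these compounds go, it also remains open whether a methoxy group at the place of that amine would restore the low number of compound 1 or stay close to compound 4.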